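Working notes: ester-side variation around compound 2

The source may report more compounds than this note shows. Statements on the series, on what has been measured and on what is new or still open speak of the compounds shown alone.

Three compounds carry numbers in an assay on isolated protein for binding affinity to Type-2 angiotensin II receptor (Homo sapiens); a higher number here means a weaker inhibitor, a lower number a stronger inhibitor. Compound 1 `CCCc1nc(CC)c(C(=O)OCc2ccccc2-c2ccccc2)n1Cc1ccc(-c2ccccc2-c2nn[nH]n2)cc1` gives 2000 nM in this assay. Compound 3 `CCCCN(Cc1ccccc1)C(=O)C#CCOC(=O)c1c(CC)nc(CCC)n1Cc1ccc(-c2ccccc2-c2nn[nH]n2)cc1` gives 400 nM in this assay. Compound 2 `CCCc1nc(CC)c(C(=O)OCc2ccccc2Sc2ccccc2)n1Cc1ccc(-c2ccccc2S(=O)(=O)NC(=O)OCCC(C)C)cc1F` gives 2 nM in this assay and so stands lowest of the three; the nearest of the others is compound 3, the furthest is compound 1, and both gaps lie beyond the usual scatter. The compounds differ from one another in several places at once, so no single change can be isolated from these numbers.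

Compound 4 `CCCc1nc(CC)c(C(=O)OCc2ccccc2OCCC(C)C)n1Cc1ccc(-c2ccccc2S(=O)(=O)NC(=O)OCCC(C)C)cc1F` has not yet been measured. It differs from compound 2 in one place: isopentyloxy in place of phenylsulfanyl on an aromatic carbon. Within the data shown here, no measured pair shows this change on its own, so its size is not known from the data. The step of a 2.5-fold higher number from compound 2 to compound 4 (0.40 log units; beyond the scatter) is expected to be small, at most a modest move upward that may not clear the scatter, since the rest of compound 2 is kept intact. Compound 4 is therefore estimated at 5 nM in this assay, with a range from 1 nM to 30 nM.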

Compound 4, half-maximal inhibitory concentration: 10 nM
For compound 4 the middle estimate is 2.0-fold (0.30 log units) below the measured one, and the stated range covers the measured number.
By their numbers in this assay, from the lowest: compound 2; then compound 4; then compound 3; then compound 1.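

In this assay, among these compounds, the exchange of phenylsulfanyl for isopentyloxy on this aromatic carbon gives a 5.0-fold higher number from compound 2 to compound 4 (0.70 log units; beyond the scatter) and is the only step here that isolates a single change. The aromatic ring leaves and a chain with no ring enters, while the hydrogen-bond acceptor count stays the same, and compound 4 still reads 10 nM. This position therefore tolerates the loss of that ring at a modest cost, though no measurement available here accounts for the step.

The step combines the loss of the ring with the exchange of sulfur for oxygen, and a phenoxy or isopentylsulfanyl group on this carbon would separate the two. Going by these compounds, how a much shorter chain such as methoxy, or an amine, would fare at this place also remains open.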